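The compounds below may be only part of what the source reports. "The series", "measured", "known", "first", "only" and "open" are said of these compounds alone.

In an ADME assay on Vero cells (Chlorocebus sabaeus) for cytotoxicity, read by MTT assay, with a stated time of 96 h (on this read-out higher numbers stand for lower toxicity in this test and lower numbers for higher toxicity in this test), three compounds have been measured so far. Compound 1 `CC(=O)c1ccc2[nH]c(-c3ccccc3)nc2c1` gives > 100000 nM, which is a limit of the assay and not a number. Compound 2 `CC(=O)c1ccc2[nH]c(-c3ccc(Cl)cc3)nc2c1` gives > 100000 nM, which is also a limit. For the measured compounds named here, compound 3 `CC(=O)c1ccc2c(c1)nc(-c1ccccc1)n2C1CCCCC1` gives 80000 nM, the only exact number available, while the other readings sit at the limit of > 100000 nM in this assay, at which 2 of the 3 values shown sit.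

Compound 4 `CC(=O)c1ccc2c(c1)nc(-c1ccc(Cl)cc1)n2C1CCCCC1` has not yet been measured. It differs from compound 3 by one swap: chloro in place of hydrogen on an aromatic carbon. This is chloro in place of hydrogen on an aromatic carbon, turning phenyl into 4-chlorophenyl.

The same swap has been made once before, giving a step that the two limits leave unreadable from compound 1 to compound 2, so it offers no size to carry over. The other measured change, cyclohexyl in place of hydrogen on an aromatic nitrogen, gave an at least 1.2-fold lower number from compound 1 to compound 3 (0.09 log units; that floor lies within the scatter). With neither step showing a clear shift, no step beyond the scatter is expected in this assay. The expected step is a 1.1-fold lower number from compound 3 to compound 4 (0.06 log units; within the scatter). Compound 4 is expected to read about 70000 nM, with an estimated range from 30000 nM to 100000 nM.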

Compound 4, half-maximal cytotoxic concentration: > 100000 nM
Compound 4: a limit, no number (the forecaster's own chance of this, stated with the estimate: 35%); middle value at least 1.4-fold (0.15 log units) from the limit.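

With the cyclohexyl group in place, the change from phenyl to 4-chlorophenyl can now be given a floor in this assay, which the earlier pair without cyclohexyl could not offer: an at least 1.2-fold higher number from compound 3 to compound 4 (0.09 log units; that floor lies within the scatter). Chloro at this position therefore gives no sign of higher toxicity in this test on the cyclohexyl compound. The steps from compound 1 to compound 2 and from compound 2 to compound 4 cannot be read, because both values in each pair are limits: the limit of > 100000 nM in this assay, at which 3 of the 4 values shown sit.

The compounds shown cannot tell how large the chloro step really is. Going by these compounds, it also stays open whether an amine or a methoxy group in place of the chloro, or a longer chain in place of the cyclohexyl on the aromatic nitrogen, would give a readable number.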